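Swapping the small ring on the side chain of compound 3

A few compounds are considered here, and "the series" means these few. Any claim that something is new, unique, unknown or untested is made for them only; others in the source may bear on it.

Three compounds share one core and differ only in the small ring that sits on a saturated chain carbon bound to an aromatic carbon and a saturated chain carbon. Compound 1 `CC(C)C(c1ccc(-c2ccc3cccc(F)c3c2)[nH]c1=O)N1CCN/C1=N\C#N` gives 23 nM in an assay on CHO cells for displacement of a labelled ligand from prostaglandin E2 receptor EP3 subtype (Homo sapiens), read by radioligand binding; on this read-out higher numbers stand for weaker inhibition and lower numbers for stronger inhibition. Compound 2 `Cc1nc(C(c2ccc(-c3ccc4cccc(F)c4c3)[nH]c2=O)C(C)C)[nH]c1C` gives 7 nM, and compound 3 `CC(C)C(c1cnc(N)s1)c1ccc(-c2ccc3cccc(F)c3c2)[nH]c1=O` gives 16 nM. On these numbers compound 3 stands second highest of the three: its nearest neighbour is compound 1, with a 1.4-fold lower number from compound 1 to compound 3 (0.16 log units; within the scatter), and its furthest is compound 2, with a 2.3-fold higher number from compound 2 to compound 3 (0.36 log units; beyond the scatter).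

Compound 4 `CC(C)C(c1noc(=O)[nH]1)c1ccc(-c2ccc3cccc(F)c3c2)[nH]c1=O` has not yet been measured. It differs from compound 3 by a group of 6 heavy atoms (2 carbon, 2 nitrogen, 2 oxygen; one five-membered aromatic ring with 3 hetero atoms) in place of a group of 6 heavy atoms (3 carbon, 2 nitrogen, 1 sulfur; one five-membered aromatic ring with 2 hetero atoms), on a saturated chain carbon bound to an aromatic carbon and a saturated chain carbon. The measured steps that bear on this are all swaps of the same small ring at the same place: a 3.3-fold lower number from compound 1 to compound 2 (0.52 log units; beyond the scatter), a 1.4-fold lower number from compound 1 to compound 3 (0.16 log units; within the scatter) and a 2.3-fold higher number from compound 2 to compound 3 (0.36 log units; beyond the scatter). Each of these stayed modest, and none moved the number by more than a few units of scatter. Among the compounds with values here, the incoming ring is a new one, so no measured pair shows its own effect.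

Compound 4 is therefore expected to land close to compound 3, with a 1.3-fold higher number from compound 3 to compound 4 (0.10 log units; within the scatter) and an estimate of 20 nM, between 7 nM and 60 nM.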

Compound 4, inhibition constant: 15 nM
The estimate for compound 4 lay 1.3-fold (0.12 log units) above the measured number; measured number inside the range.
By their numbers in this assay, from the lowest: compound 2; then compounds 4, 3 and 1 (each within the scatter of the next).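

In this assay, a ring holding oxygen in place of sulfur is accepted on this saturated chain carbon, with a 1.1-fold lower number from compound 3 to compound 4 (0.03 log units; within the scatter). The new ring also sits within the scatter of the larger non-aromatic group of compound 1, with a 1.5-fold lower number from compound 1 to compound 4 (0.19 log units; within the scatter), so three quite different groups now give numbers that cannot be told apart from the pairs read so far, or differ only slightly. The one clear separation remains the 4,5-dimethyl-1H-imidazol-2-yl ring, with a 2.1-fold higher number from compound 2 to compound 4 (0.33 log units; beyond the scatter), a modest step that leaves compound 2 with the lowest number of the four, and no measurement at hand says what sets this ring apart.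

The compounds shown leave open whether the 4,5-dimethyl-1H-imidazol-2-yl ring would keep its edge without its methyl groups, which would show whether the ring itself or those added carbons go with the lower number. They also leave open whether a ring is needed here at all, since an open-chain group such as a carboxylic acid or a simple amine at this place would test that directly.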